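A few compounds are considered here, and "the series" means these few. Any claim that something is new, unique, unknown or untested is made for them only; others in the source may bear on it.

Measured in a functional assay on HeLa cells (Homo sapiens) for antiproliferative activity, read by CCK-8 assay, with a stated time of 72 h; a lower number here means a stronger inhibitor of growth, a higher number a weaker inhibitor of growth:
- Compound 1 `CCC1C(=O)N(C)c2cnc(-n3ccc4cc(C(=O)NC)ccc43)nc2N1c1ccn(C)n1`: 6330 nM
- Compound 2 `CC[C@@H]1C(=O)N(C)c2cnc(-n3ccc4cc(F)ccc43)nc2N1C1CCCC1`: "not active" (no number reported)
- Compound 3 `CC[C@@H]1C(=O)N(C)c2cnc(Nc3ccc(S(=O)(=O)NCCO)cc3)nc2N1C1CCCC1`: 459 nM

Compound 1 has the higher of the two numbers, so it is the weaker growth inhibitor of the pair. Compound 3 sits lower by more than the usual scatter, and compound 2 gave no number at all. Compound 4 `CCC1C(=O)N(C)c2cnc(-n3ccc4cc(C(=O)NC5CCCC5)ccc43)nc2N1c1ccn(C)n1` keeps the rest of compound 1 and makes one change: cyclopentyl in place of methyl on an amide-type nitrogen. Among the measured compounds shown here, no measured pair shows this change, so no step beyond the scatter is expected in this assay, and no direction can be favoured. The estimate is a 1.3-fold lower number from compound 1 to compound 4 (0.10 log units; within the scatter). For compound 4 the estimated value is 5000 nM, with an expected range of 1500 nM to 17000 nM.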

Compound 4, concentration for 50% growth inhibition: 27400 nM
Compound 4: the middle estimate sits 5.5-fold (0.74 log units) below what was measured; measured number outside the range, above it.
By their numbers in this assay, from the lowest: compound 3; then compound 1; then compound 4.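

In this assay, the group on this amide-type nitrogen matters: cyclopentyl in place of methyl gives a 4.3-fold higher number from compound 1 to compound 4 (0.64 log units; beyond the scatter), so the growth-inhibiting effect weakens. Among the compounds shown here, this is the only measured step at this position, and it shows that the position does not accept this change without loss. Nothing measured here accounts for the step.

Going by these compounds, whether an ethyl or a cyclopropyl group on the same nitrogen would behave more like methyl or more like cyclopentyl remains open. So does whether the same change would weaken compounds with a different group elsewhere.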